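This account rests on a few compounds, and the source may have more. Where it says the series, first, only, none or still open, it means among the compounds named here.

Measured so far in an ADME assay on HEp-2 cells (Homo sapiens) for cytotoxicity (a higher number here means that more compound is tolerated, a lower number that less compound is tolerated), three compounds have values.

- Compound 1 `Cc1cccc(NC(=O)[C@@H]2CCCN2S(=O)(=O)c2cccc3cccnc23)c1` gives 25500 nM
- Compound 2 `CC(C)c1ccccc1NC(=O)[C@@H]1CCCN1S(=O)(=O)c1cccc2cccnc12` gives 29900 nM
- Compound 3 `COc1ccc(C)c(NC(=O)[C@@H]2CCCN2S(=O)(=O)c2cccc3cccnc23)c1` gives 44200 nM

Compound 3 does not stand apart from the other two. The data show a 1.7-fold higher number from compound 1 to compound 3 (0.24 log units; within the scatter) and a 1.5-fold higher number from compound 2 to compound 3 (0.17 log units; within the scatter), so all of its differences lie within the normal spread of repeat measurements.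

Compound 4 `Cc1cc(NC(=O)[C@@H]2CCCN2S(=O)(=O)c2cccc3cccnc23)n(C(C)(C)C)n1` keeps the shared core and differs from compound 3 in a single place, on an amide-type nitrogen: 3-methyl-1-(tert-butyl)-1H-pyrazol-5-yl in place of 5-methoxy-2-methylphenyl on an amide-type nitrogen. Here 3-methyl-1-(tert-butyl)-1H-pyrazol-5-yl, a five-membered aromatic ring with 2 hetero atoms, takes the place of 5-methoxy-2-methylphenyl, a six-membered aromatic ring of carbon only.

All three measured steps exchange the group at this same nitrogen. They include a 1.2-fold higher number from compound 1 to compound 2 (0.07 log units; within the scatter), and even a 1.7-fold higher number from compound 1 to compound 3 (0.24 log units; within the scatter) stays within the scatter. From the compounds shown here alone, every measured compound carries a six-membered ring of carbon only there, so a five-membered ring with hetero atoms is untested, and the range must be generous. In this assay the expected outcome is a 1.3-fold lower number from compound 3 to compound 4 (0.10 log units; within the scatter), meaning no step beyond the scatter. Compound 4 is estimated at 35000 nM. The expected range for compound 4 runs from 16000 nM to 75000 nM.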

Compound 4, half-maximal cytotoxic concentration: > 50000 nM
Compound 4 was reported as a limit; the forecaster's own chance of this, stated with the estimate: 10%; at least 1.4-fold (0.15 log units) between middle value and limit.
By their numbers in this assay, from the lowest: compounds 1, 2 and 3 (each within the scatter of the next). At a limit, above all of these: compound 4.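

In this assay compound 4 gives > 50000 nM, which is a limit of the assay and not a number. For the compounds shown here, this is the first sign that the amide-type nitrogen accepts something other than a six-membered aromatic ring of carbon only, since 3-methyl-1-(tert-butyl)-1H-pyrazol-5-yl, a five-membered aromatic ring with 2 hetero atoms, brings no drop in the tolerated amount; the steps read an at least 1.1-fold higher number from compound 3 to compound 4 (0.05 log units; that floor lies within the scatter), an at least 1.6-fold higher number from compound 2 to compound 4 (0.22 log units; that floor lies within the scatter) and an at least 1.9-fold higher number from compound 1 to compound 4 (0.29 log units; that floor lies within the scatter). Each of these floors lies within the scatter, so the real size of the change cannot be read, and the one new fact is that a single compound now sits at the top of the measurable range: the limit of > 50000 nM in this assay, at which 1 of the 4 values shown sits.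

The compounds shown leave open how far past its limit compound 4 really lies, and whether the five-membered ring or its tert-butyl group matters more for this result. Also open, from the compounds shown here alone, is how a ring carrying an amine or a carboxylic acid, or a plain alkyl chain in place of the ring, would behave on this nitrogen in this assay.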